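One Methyl-to-Methoxy Change, Tried on a Second Core

The source may hold more compounds than are shown below. What is called first, only, known or untested is meant among the compounds shown, and "the series" means these compounds.

Compound 1 `COc1ccc(CN(C(=O)CSC(=S)N2CCCc3cc(C)ccc32)c2cc(OC)c(OC)c(OC)c2)cc1` was tested in a functional assay on HCT-116 cells (Homo sapiens) for inhibition, read by CCK-8 assay, with a stated time of 48 h (a lower number here means a stronger inhibitor, a higher number a weaker inhibitor), and gave 5230 nM. Compound 2 `COc1ccc(CN(C(=O)CSC(=S)N2CCCc3cc(OC)ccc32)c2cc(OC)c(OC)c(OC)c2)cc1` carries the change (methoxy in place of methyl on an aromatic carbon). In this assay compound 2 reached only the limit of > 20000 nM. The result is an at least 3.8-fold higher number from compound 1 to compound 2 (0.58 log units; beyond the scatter), a step whose size is set by the limit of > 20000 nM in this assay, at which 2 of the 3 values shown sit. Compound 3 `COc1ccc(CN(C(=O)CSC(=S)N2CCN(C(=O)OC(C)(C)C)CC2)c2ccc(C)cc2)cc1` rests on a different core; the difference between the two cores is not broken down here. In this assay compound 3 likewise reached only the limit of > 20000 nM. Compound 4 `COc1ccc(CN(C(=O)CSC(=S)N2CCN(C(=O)OC(C)(C)C)CC2)c2ccc(OC)cc2)cc1` makes the same kind of change, (methoxy in place of methyl on an aromatic carbon), though here the place is para to a large group rather than part of a fused or bridged system of two rings, meta to a fused ring and para to a fused ring. Compound 4 is expected to show a step that the limit leaves unreadable from compound 3 to compound 4. This expectation rests on compound 3, which stands at the limit of > 20000 nM. It rests also on the earlier step, an at least 3.8-fold higher number from compound 1 to compound 2 (0.58 log units; beyond the scatter). Compound 4 is therefore estimated at 30000 nM, most likely again as a limit.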

Compound 4, half-maximal inhibitory concentration: > 20000 nM
Compound 4 was reported as a limit; the forecaster's own chance of this, stated with the estimate: 85%; the middle value lies beyond the limit too.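

In this assay, compound 3 and compound 4 both stand at a limit, so no step between them can be read: the limit of > 20000 nM in this assay, at which 3 of the 4 values shown sit.

The compounds shown leave open whether methoxy in place of methyl raises the number on this second core, as it did on the core of compound 1.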